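Halogen Swaps on the Sulfonamide Aryl Ring

A few compounds are considered here, and "the series" means these few. Any claim that something is new, unique, unknown or untested is made for them only; others in the source may bear on it.

Of the compounds shown here, three on a shared core have been measured in an assay on isolated protein for binding affinity to 5-hydroxytryptamine receptor 6 (Homo sapiens); a higher number here means a weaker inhibitor, a lower number a stronger inhibitor. Compound 1, `COc1ccc(S(=O)(=O)Nc2cc(Br)cc(Br)c2Br)cc1N1CCNCC1`, gives 2.51 nM. Compound 2, `COc1ccc(S(=O)(=O)Nc2cc(Br)cc(Br)c2F)cc1N1CCNCC1`, gives 2.51 nM. Compound 3, `COc1ccc(S(=O)(=O)Nc2cc(Br)cc(F)c2Cl)cc1N1CCNCC1`, gives 3.16 nM. The change from compound 1 to compound 2 is fluoro in place of bromo on an aromatic carbon; it brought no change at the digits printed from compound 1 to compound 2 (within the scatter). The cores of compound 1 and compound 3 differ by 5-bromo-2-chloro-3-fluorophenyl in place of 2,3,5-tribromophenyl on a sulfonamide nitrogen, and the step between them is a 1.3-fold higher number from compound 1 to compound 3 (0.10 log units; within the scatter). Compound 2 and compound 3 are related by a 1.3-fold higher number from compound 2 to compound 3 (0.10 log units; within the scatter).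

Compound 4, `COc1ccc(S(=O)(=O)Nc2cc(F)cc(F)c2Cl)cc1N1CCNCC1`, has not yet been measured. It differs from compound 3 by fluoro in place of bromo on an aromatic carbon. This is the same kind of change as that from compound 1 to compound 2, but the surroundings differ: in compound 1 the replaced bromo sits ortho to a bromo group, ortho to a large group and para to a bromo group, whereas in compound 3 it sits meta to a fluoro group, meta to a large group and para to a chloro group. Because the same kind of change gave no change at the digits printed from compound 1 to compound 2 (within the scatter), compound 4 is expected to move only by a 1.1-fold higher number from compound 3 to compound 4 (0.04 log units; within the scatter) in this assay. Compound 4 is therefore estimated at 3.5 nM, within 1.5 nM to 8 nM.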

Compound 4, inhibition constant: 31.6 nM
The estimate for compound 4 lay 9.0-fold (0.96 log units) below the measured number; the whole stated range lies below it.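

In this assay, fluoro in place of bromo gave a 10-fold higher number from compound 3 to compound 4 (1.00 log units; beyond the scatter), and the 2-chloro-3,5-difluorophenyl group of compound 4 also stands apart from the other two compounds, with a 13-fold higher number from compound 2 to compound 4 (1.10 log units; beyond the scatter) and a 13-fold higher number from compound 1 to compound 4 (1.10 log units; beyond the scatter). The change therefore did not carry from one core to the other with the same size: the same change on two cores in this assay, no change at the digits printed (within the scatter) from compound 1 to compound 2 and a 10-fold higher number (1.00 log units; beyond the scatter) from compound 3 to compound 4, 10-fold (1.00 log units) apart, beyond the scatter of two such steps. This shows that a silent step on one core in this series does not foretell the step on another, but two cases do not show what sets the gap between them, and they say nothing about how the change would behave on any further core.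

The compounds shown leave open whether the higher number of compound 4 belongs to the fluoro that enters or to the bromo that leaves. A methyl group, a nitrile or a plain hydrogen in place of that bromo on the core of compound 3 would help tell these two readings apart.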